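The source may report more compounds than this note shows. Statements on the series, on what has been measured and on what is new or still open speak of the compounds shown alone.

Compound 1 `O=C(Nc1ccccn1)c1ccccc1` is the reference for this account. In an assay on isolated protein (Aquatica lateralis) for inhibition of Luciferin 4-monooxygenase (Luciola lateralis), read by a luciferase reporter, tested at 10 uM (a higher number here means more inhibition at the concentration tested (going by the name of the read-out), a lower number less inhibition), compound 1 gives 27%, which places it second highest among the three numbers at hand, though both gaps are within the scatter. Its nearest neighbour is compound 2 `O=C(Nc1cccc(-c2ccccc2)n1)c1ccccc1`, which in this assay gives 30%, and the furthest is compound 3 `c1ccc(CNc2ccc(-c3ccccc3)cn2)cc1`, which gives 20%.

The unmeasured compound 4 `O=C(Nc1ccc(-c2cccc(Cl)c2)cn1)c1ccccc1` differs from compound 1 by 3-chlorophenyl in place of hydrogen on an aromatic carbon. For the measured compounds named here, the only measured step that bears on this change is a number 3 percentage points higher from compound 1 to compound 2 (within the scatter), where a phenyl likewise replaced a hydrogen on an aromatic carbon of the shared core, though at another place. That step stayed within the scatter, so a shift in this assay beyond the scatter is not expected in either direction for compound 4 on this evidence.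

Compound 4 is therefore estimated at 28%, with a range from 10% to 46%, which would mean an expected step of a number 1 percentage points higher from compound 1 to compound 4 (within the scatter).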

Compound 4, a percentage reported as inhibition, at one concentration (the size of the read-out at that concentration, not a potency): 38%
Estimate against measurement, compound 4: 10 percentage points below; measured number inside the range.
By their numbers in this assay, from the lowest: compounds 3, 1, 2 and 4 (each within the scatter of the next, the first and the last beyond it).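

In this assay there is a rise of a number 11 percentage points higher from compound 1 to compound 4 (beyond the scatter), so a substituent on this aromatic carbon, two atoms from the ring nitrogen and para to a group of 9 heavy atoms, can move the number beyond the scatter. The earlier step, a number 3 percentage points higher from compound 1 to compound 2 (within the scatter), stayed within the scatter, with phenyl at another place on the shared core. Compound 4 thus gives the first sign that replacing hydrogen with an aromatic ring can matter, though the step is modest and rests on this single pair, and no measurement at hand accounts for it.

The compounds shown do not separate the contribution of the chlorine from that of the ring, as plain phenyl at this same place is absent from them. Also open, as far as these compounds go, is how an amine or a carboxylic acid in place of the chlorine would read in this assay.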